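From Fluoro to a Pyrrolidinyl Amide Side Chain

The source may report more compounds than this note shows. Statements on the series, on what has been measured and on what is new or still open speak of the compounds shown alone.

Compound 2 `Fc1ccc(-c2nc3cc(C(F)(F)F)ccc3[nH]2)cc1` gives the highest of the two numbers shown: in an ADME assay on MT4 cells (Homo sapiens) for cytotoxicity, read by MTT assay, with a stated time of 96 h (on this read-out higher numbers stand for lower toxicity in this test and lower numbers for higher toxicity in this test), compound 2 gives 22000 nM, whereas compound 1 `CCN(CC)CC(=O)Nc1ccc(-c2nc3cc(C(F)(F)F)ccc3[nH]2)cc1` gives 8000 nM. Going by the values given here, the one measured step, a 2.8-fold higher number from compound 1 to compound 2 (0.44 log units; beyond the scatter), shows what replacing such an amide-bearing side chain by fluoro did. Compound 3 `O=C(CN1CCCC1)Nc1ccc(-c2nc3cc(C(F)(F)F)ccc3[nH]2)cc1` differs from compound 2 as follows: (((pyrrolidin-1-yl)methyl)carbonyl)amino in place of fluoro on an aromatic carbon. Because compound 1 with its 8000 nM carries a side chain close to the one that enters here, the earlier step is expected to run backwards. For compound 3 a lower number is expected, a 2.4-fold lower number from compound 2 to compound 3 (0.39 log units; beyond the scatter). The estimate for compound 3 in this assay is 9000 nM, ranging from 4000 nM to 20000 nM.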

Compound 3, half-maximal cytotoxic concentration: 18000 nM
Beside the measured number, compound 3's estimate is 2.0-fold (0.30 log units) below it, within the range that was stated.
By their numbers in this assay, from the lowest: compound 1; then compounds 3 and 2 (each within the scatter of the next).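

At this position, para to a large group, the step of a 1.2-fold lower number from compound 2 to compound 3 (0.09 log units; within the scatter) is small enough that in this assay the pyrrolidinyl amide side chain and fluoro cannot be told apart. An amide side chain here therefore does not by itself bring the lower number of compound 1. The step of a 2.3-fold higher number from compound 1 to compound 3 (0.35 log units; beyond the scatter) places the difference at the chain's amine end, where pyrrolidin-1-yl stands in place of diethylamino. From the compounds shown here alone, whether a piperidine or morpholine ring at that end would track compound 3 or compound 1 stays open. Nothing at hand explains the difference between these two amine ends.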